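Adding a hydroxy group to a weakly binding benzyloxy compound

A few compounds are considered here, and "the series" means these few. Any claim that something is new, unique, unknown or untested is made for them only; others in the source may bear on it.

Measured so far:
compound 1, `Nc1nc(OCc2ccccc2)c2[nH]c(O)nc2n1`, 0.3 uM
compound 2, `Oc1nc(OCc2ccccc2)c2[nH]cnc2n1`, 60 uM

Of the compounds shown here, two have been tested in an assay on HT-29 cells with Methylated-DNA--protein-cysteine methyltransferase (Homo sapiens) as the target, with a stated time of 30 min; on this read-out lower numbers stand for an effect already at smaller amounts and higher numbers for an effect only at larger amounts of compound. Compound 1 gives 0.3 uM, whereas compound 2 gives 60 uM. Compound 2 therefore stands at the higher of the two numbers, and its gap to compound 1 is far wider than the usual scatter of such measurements. Among the measured compounds shown here, the two differ in more than one place, so no single step between them can be read off.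

The next compound, compound 3, `Oc1nc(OCc2ccccc2)c2[nH]c(O)nc2n1`, keeps the whole of compound 2 and changes it in one place: hydroxy in place of hydrogen on an aromatic carbon. For the measured compounds named here, no pair of measured compounds shows this exact change on its own, so its effect has to be estimated rather than read from the data. A modest move toward a lower number is expected, though a result within the scatter of compound 2 would not be surprising; the step from compound 2 to compound 3 is expected to be a 4.0-fold lower number from compound 2 to compound 3 (0.60 log units; beyond the scatter). For compound 3 the value in this assay is expected to be about 15 uM, with a likely range from 3 uM to 60 uM.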

Compound 3, concentration for half-maximal effect: 25 uM
The estimate for compound 3 lay 1.7-fold (0.22 log units) below the measured number; measured number inside the range.
By their numbers in this assay, from the lowest: compound 1; then compound 3; then compound 2.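

In this assay, hydroxy in place of hydrogen on the aromatic carbon between two ring nitrogen atoms gives a 2.4-fold lower number from compound 2 to compound 3 (0.38 log units; beyond the scatter), a modest step but beyond the scatter, so this position does respond to the change. Compound 3 also links the two earlier compounds, which differ in more than one place: hydroxy in place of amino on an aromatic carbon gives an 83-fold higher number from compound 1 to compound 3 (1.92 log units; beyond the scatter), a large step. Of the two single changes that can now be read, the swap between amino and hydroxy therefore moves the number much further than the swap between hydrogen and hydroxy. Nothing available explains the size of either step.

On these data alone, how large the step from hydrogen to hydroxy would be with the amino group in place remains open, since it can be read here only in a compound that carries hydroxy rather than amino. As far as these compounds go, it is also open whether another group on the carbon between two ring nitrogen atoms, such as an amine or a methoxy group, would lower the number further than hydroxy does.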